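A few compounds are considered here, and "the series" means these few. Any claim that something is new, unique, unknown or untested is made for them only; others in the source may bear on it.

Measured in a functional assay on MCF7 cells (Homo sapiens) for cytotoxicity, read by MTT assay, with a stated time of 96 h; on this read-out higher numbers stand for weaker inhibition and lower numbers for stronger inhibition:
- compound 1 `COc1cc(C(=O)c2cn(-c3cccc(C)c3)cc2-c2ccccc2Cl)cc(OC)c1OC`: 420 nM
- compound 2 `COc1cc(C(=O)c2cn(-c3cccc(N)c3)cc2-c2ccccc2Cl)cc(OC)c1OC`: 40 nM
- compound 3 `COc1cc(C(=O)c2cn(-c3ccc(C)cc3)cc2-c2ccccc2Cl)cc(OC)c1OC`: 180 nM

Compound 3, at 180 nM, holds the middle number of the three. It is separated from the others by a 2.3-fold lower number from compound 1 to compound 3 (0.37 log units; beyond the scatter) and a 4.5-fold higher number from compound 2 to compound 3 (0.65 log units; beyond the scatter).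

Next is compound 4 `COc1cc(C(=O)c2cn(-c3ccc(N)cc3)cc2-c2ccccc2Cl)cc(OC)c1OC`, with the change amino in place of methyl on an aromatic carbon, para to a large group. The same exchange elsewhere on the ring gave an 11-fold lower number from compound 1 to compound 2 (1.02 log units; beyond the scatter), a large step. The a 2.3-fold lower number from compound 1 to compound 3 (0.37 log units; beyond the scatter) shows that the position of the methyl also matters in this assay. For the measured compounds named here, only one pair supports the exchange, so a large step to a lower number is expected, somewhat smaller than that precedent. The expected change is a 5.6-fold lower number from compound 3 to compound 4 (0.75 log units; beyond the scatter). For compound 4 the estimate is 32 nM, with an expected range of 10 nM to 100 nM.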

Compound 4, half-maximal inhibitory concentration: 83 nM
The estimate for compound 4 lay 2.6-fold (0.41 log units) below the measured number; the range from low to high includes it.
By their numbers in this assay, from the lowest: compound 2; then compound 4; then compound 3; then compound 1.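

Amino in place of methyl also lowers the number in this assay para to a large group, with a 2.2-fold lower number from compound 3 to compound 4 (0.34 log units; beyond the scatter), but the size of this step differs with the ring position: the same change on two cores in this assay, an 11-fold lower number (1.02 log units; beyond the scatter) from compound 1 to compound 2 and a 2.2-fold lower number (0.34 log units; beyond the scatter) from compound 3 to compound 4, 4.8-fold (0.68 log units) apart, beyond the scatter of two such steps. Among the amino compounds, 3-aminophenyl gives the lower number, with a 2.1-fold higher number from compound 2 to compound 4 (0.32 log units; beyond the scatter), the reverse of the order among the methyl compounds. Across both changes, 4-aminophenyl stands well under 3-methylphenyl, with a 5.1-fold lower number from compound 1 to compound 4 (0.70 log units; beyond the scatter). Open, going by these compounds, is whether a hydroxyl or a dimethylamino group in these two places would follow the amino group.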